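Trifluoromethoxy in Place of Chloro on Compound 1

A few compounds are considered here, and "the series" means these few. Any claim that something is new, unique, unknown or untested is made for them only; others in the source may bear on it.

Compound 1 `CN1CCN(CCCNCc2cn(-c3ccc([N+](=O)[O-])cc3)nc2-c2ccc(Cl)cc2)CC1` gives 3700 nM in an ADME assay on Huh-7 cells (Homo sapiens) for cytotoxicity (on this read-out higher numbers stand for lower toxicity in this test and lower numbers for higher toxicity in this test), the lowest of the three numbers measured. Compound 2 `Cc1ccccc1-c1nn(-c2ccc(Cl)cc2)cc1CNCCN1CCN(C)CC1` gives 17000 nM and compound 3 `Cc1ccccc1-c1nn(-c2ccc(Br)cc2)cc1CNCCN1CCN(C)CC1` gives 9600 nM; both stand higher than compound 1 by more than the scatter. Compound 4 `CN1CCN(CCCNCc2cn(-c3ccc([N+](=O)[O-])cc3)nc2-c2ccc(OC(F)(F)F)cc2)CC1` differs from compound 1 by trifluoromethoxy in place of chloro on an aromatic carbon. Among the compounds with values here, the only measured step, a 1.8-fold lower number from compound 2 to compound 3 (0.25 log units; within the scatter), concerns bromo in place of chloro on other compounds and is within the scatter, so it offers no direct guide to a trifluoromethoxy group. Within the data shown here, no measured compound carries this group, and no direction can be read from the data. For compound 4 the change a 1.1-fold higher number from compound 1 to compound 4 (0.03 log units; within the scatter) is expected to stay within the scatter. The estimate for compound 4 is 4000 nM, ranging from 1500 nM to 11000 nM.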

Compound 4, half-maximal cytotoxic concentration: 1600 nM
Beside the measured number, compound 4's estimate is 2.5-fold (0.40 log units) above it, within the range that was stated.
By their numbers in this assay, from the lowest: compound 4; then compound 1; then compounds 3 and 2 (each within the scatter of the next).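

In this assay, trifluoromethoxy in place of chloro on this aromatic carbon gives a 2.3-fold lower number from compound 1 to compound 4 (0.36 log units; beyond the scatter), a modest step towards higher toxicity in this test. The earlier step, a 1.8-fold lower number from compound 2 to compound 3 (0.25 log units; within the scatter), concerned bromo in place of chloro on other compounds and stayed within the scatter, so this is the first change shown to move the number beyond it. No measurement shown here explains the shift. Open, as far as these compounds go, is how a methoxy group or an amine on this carbon would compare, and whether trifluoromethoxy would produce a similar step on compound 2.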